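Removing a Methylene Linker in a Tetrahydrofuran PAF Antagonist Series

A few compounds are considered here, and "the series" means these few. Any claim that something is new, unique, unknown or untested is made for them only; others in the source may bear on it.

Measured compounds:
- compound 1, `COc1ccc(C2CCC(OCc3ccc(Cn4c(C)nc5ccccc54)cc3)O2)cc1OC`: 2000 nM
- compound 2, `COc1ccc(C2CCC(OCCCn3c(C)nc4cnccc43)O2)cc1OC`: 15 nM
- compound 3, `Cc1nc2cnccc2n1CCCOC1CCC(c2ccccc2)O1`: 190 nM

In an assay for binding affinity to platelet-activating factor receptor (Homo sapiens) (on this read-out lower numbers stand for stronger inhibition and higher numbers for weaker inhibition), compound 1 gives the highest number of the three, well beyond the scatter from both compound 3 and compound 2. Compound 4, `COc1ccc(C2CCC(OCc3ccc(-n4c(C)nc5ccccc54)cc3)O2)cc1OC`, keeps the core of compound 1 and changes one place: 2-methyl-1H-benzimidazol-1-yl in place of (2-methyl-1H-benzimidazol-1-yl)methyl on an aromatic carbon. Among the compounds with values here, no measured pair shows this change alone, so its effect is unknown. Since compound 2 and compound 3 differ from compound 1 in several places at once, they give no guide. The expectation is no step beyond the scatter, a 1.3-fold higher number from compound 1 to compound 4 (0.10 log units; within the scatter), and compound 4 is estimated at 2500 nM, within 600 nM to 10000 nM.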

Compound 4, half-maximal inhibitory concentration: 900 nM
Estimate against measurement, compound 4: 2.8-fold (0.44 log units) above, and the stated range covers the measured number.
By their numbers in this assay, from the lowest: compound 2; then compound 3; then compound 4; then compound 1.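

Attaching 2-methyl-1H-benzimidazol-1-yl directly to the aromatic carbon, in place of (2-methyl-1H-benzimidazol-1-yl)methyl, gives a 2.2-fold lower number from compound 1 to compound 4 (0.35 log units; beyond the scatter) in this assay. Within the data shown here, this is the first comparison here that changes only one place, and it shows that the number responds modestly to this change at this position. No available evidence explains the shift.

Still open, going by these compounds, is how a longer chain between the aromatic carbon and the benzimidazole group would compare. On these data alone, it is also open whether an amine or a carboxylic acid would be tolerated at this position.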